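The source may hold more compounds than are shown below. What is called first, only, known or untested is meant among the compounds shown, and "the series" means these compounds.

Working notes on the series. In an in vitro assay on HEK385-7 cells for displacement of a labelled ligand from prostaglandin D2 receptor 2 (Homo sapiens) (a lower number here means a stronger inhibitor, a higher number a weaker inhibitor), compound 1 `N#Cc1ccc(-c2nc(C(c3ccc(F)cc3)c3ccc(F)cc3)sc2CC(=O)O)cc1` gives 150 nM, and compound 2 `CN(C)c1cc(-c2nc(C(c3ccc(F)cc3)c3ccc(F)cc3)sc2CC(=O)O)ccn1` gives 380 nM. Going by the values given here, compound 2 therefore holds the higher of the two numbers in this assay, with compound 1 as its only neighbour, and the one measured step, a 2.5-fold higher number from compound 1 to compound 2 (0.40 log units; beyond the scatter), concerns the aryl group as a whole rather than any substituent on it. Compound 3 `O=C(O)Cc1sc(C(c2ccc(F)cc2)c2ccc(F)cc2)nc1-c1ccnc(N2CCCC2)c1` differs from compound 2 by pyrrolidin-1-yl in place of dimethylamino on an aromatic carbon. Among the compounds with values here, no measured step bears on this exact change: the only step recorded, a 2.5-fold higher number from compound 1 to compound 2 (0.40 log units; beyond the scatter), swaps one aryl for another and gives no guide to varying the amine substituent on the same ring. With nothing to anchor a direction, the expected step from compound 2 to compound 3 in this assay is small, a 1.3-fold lower number from compound 2 to compound 3 (0.10 log units; within the scatter), likely within the scatter. Compound 3 is accordingly estimated at 300 nM in this assay, with a range of 100 nM to 900 nM.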

Compound 3, half-maximal inhibitory concentration: 230 nM
The estimate for compound 3 lay 1.3-fold (0.12 log units) above the measured number; measured number inside the range.
By their numbers in this assay, from the lowest: compounds 1, 3 and 2 (each within the scatter of the next, the first and the last beyond it).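

On the carbon next to the ring nitrogen, in this assay, pyrrolidin-1-yl in place of dimethylamino gives a 1.7-fold lower number from compound 2 to compound 3 (0.22 log units; within the scatter) and so shows that this position accepts a ring-closed amine as well as an open one, with no change beyond the scatter. The step of a 1.5-fold higher number from compound 1 to compound 3 (0.19 log units; within the scatter) also lies within the scatter, so with pyrrolidin-1-yl on the pyridin-4-yl ring, the replacement of 4-cyanophenyl no longer gives a difference beyond the scatter, as it did for compound 2. No measurement here offers an explanation for either step.

As far as these compounds go, it remains open whether piperidin-1-yl, morpholin-4-yl or an unsubstituted amino group on this carbon would stay within the scatter of compound 3. From the compounds shown here alone, it is also open whether pyrrolidin-1-yl on a phenyl ring would read the same as on the pyridin-4-yl ring, which would separate the contribution of the amine from that of the ring nitrogen.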